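Replacing Carboxy with Methanesulfonamido at the Assay Limit

The source may report more compounds than this note shows. Statements on the series, on what has been measured and on what is new or still open speak of the compounds shown alone.

compound 1 `COc1ccc(S(=O)(=O)Nc2cccc3cc[nH]c23)cc1`: 1.1 ug/mL
compound 2 `O=S(=O)(Nc1cccc2cc[nH]c12)c1ccc(Cl)cc1`: 6 ug/mL
compound 3 `N#Cc1c[nH]c2c(NS(=O)(=O)c3ccc(C(=O)O)cc3)cccc12`: > 100 ug/mL (a limit, not a number)

These three compounds were tested in a functional assay on P388 cells (Mus musculus) for antiproliferative activity; a higher number here means a weaker inhibitor, a lower number a stronger inhibitor. Compound 3 gives > 100 ug/mL, which is a limit of the assay and not a number. Its true value is therefore unknown.

Compound 4 `CS(=O)(=O)Nc1ccc(S(=O)(=O)Nc2cccc3c(C#N)c[nH]c23)cc1` has not yet been measured. It differs from compound 3 by a single change: methanesulfonamido in place of carboxy on an aromatic carbon. This places methanesulfonamido in place of carboxy on an aromatic carbon, para to a large group.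

Within the data shown here, only one measured step offers a guide: a 5.5-fold higher number from compound 1 to compound 2 (0.74 log units; beyond the scatter). That step, chloro in place of methoxy on an aromatic carbon, shows that one swapped group can move the number beyond the scatter. It is a different swap, however, so it guides the size only loosely. Compound 1 gives 1.1 ug/mL and compound 2 gives 6 ug/mL, and neither carries a carboxy. A clearly lower number is therefore expected, probably by more than the measured step. The estimated change is an at least 12-fold lower number from compound 3 to compound 4 (1.09 log units; beyond the scatter). For compound 4 the estimate is 8 ug/mL, with an expected range from 1 ug/mL to 60 ug/mL.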

Compound 4, half-maximal inhibitory concentration: 3.5 ug/mL
For compound 4 the middle estimate is 2.3-fold (0.36 log units) above the measured one; the range from low to high includes it.
By their numbers in this assay, from the lowest: compound 1; then compounds 4 and 2 (each within the scatter of the next). At a limit, above all of these: compound 3.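

In this assay compound 3 gives > 100 ug/mL and this is a limit of the assay, not a number: the limit of > 100 ug/mL in this assay, at which 1 of the 4 values shown sits.

Among these compounds, putting methanesulfonamido in place of carboxy, para to a large group, gives an at least 28-fold lower number from compound 3 to compound 4 (1.45 log units; beyond the scatter) and so shows that a single exchange at this aromatic carbon can produce a large change, whereas the only earlier step, a different exchange, was modest. Compound 4 also shows that a compound carrying the nitrile can give a readable number in this assay when methanesulfonamido replaces carboxy, so the nitrile alone does not hold the series at the limit.

The true size of the step stays unknown, and the exchange alters several things at once, so the compounds shown cannot tell which part of methanesulfonamido matters. On these data alone, how an amine or an acetamido group would behave at this carbon remains open, as does whether the same exchange would give a similar step on a core without the nitrile.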